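A few compounds are considered here, and "the series" means these few. Any claim that something is new, unique, unknown or untested is made for them only; others in the source may bear on it.

Measured compounds:
compound 1 `COc1ccccc1/C=C/C(=O)OC/C=C/c1cc(OC)c(OC)cc1OC` — 100%
compound 2 `COc1cc(OC)c(OC)cc1/C=C/COC(=O)/C=C/c1c(OC)ccc(OC)c1OC` — 100%
compound 3 `COc1cc(OC)c(OC)cc1/C=C/COC(=O)/C=C/c1cccc(Br)c1` — 100%

In a functional assay on the whole organism (strain Kunming) with Mus musculus as the target, with a stated time of 0.5 h, at a dose of 100 mg/kg by the intraperitoneal route (a lower number here means a stronger effect, a higher number a weaker effect of the compound at the dose given), compound 1 gives 100%. Compound 2 gives 100% in this assay, and compound 3 gives 100%. Compound 3 thus stands level with compounds 1 and 2 at the digits shown; its nearest neighbour in value is compound 1 and its furthest is compound 2, both within the scatter. Going by the values given here, the single step between measured compounds that differ in one place runs no change at the digits printed from compound 1 to compound 3 (within the scatter): 3-bromophenyl in place of 2-methoxyphenyl on a double-bonded chain carbon bound to a double-bonded chain carbon left the read-out unchanged.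

Compound 4 `COc1ccc(/C=C/C(=O)OC/C=C/c2cc(OC)c(OC)cc2OC)cc1` has not yet been measured in this assay. It differs from compound 3 as follows: 4-methoxyphenyl in place of 3-bromophenyl on a double-bonded chain carbon bound to a double-bonded chain carbon. The step from compound 1 to compound 3 bears on this directly, since the group at the same place is exchanged in both, and that step was flat. Nothing measured separates a methoxyphenyl from a bromophenyl at this place, so no step beyond the scatter is expected in this assay, in either direction. For compound 4 the estimate is 100%, with a range from 88% to 100%. The step expected is no change at the digits printed from compound 3 to compound 4 (within the scatter).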

Compound 4, a percentage reported as activity, at one dose (the size of the read-out at that dose, not a potency): 100%
The estimate for compound 4 equals the measured number at the digits printed, and the stated range covers the measured number.
By their numbers in this assay, from the lowest: compounds 1, 2, 3 and 4 (each within the scatter of the next).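

In this assay, the read-out runs no change at the digits printed from compound 3 to compound 4 (within the scatter), so 4-methoxyphenyl in place of 3-bromophenyl on a double-bonded chain carbon bound to a double-bonded chain carbon makes no difference, even though the entering group carries an oxygen and a hydrogen-bond acceptor that the leaving group lacks. Going by these compounds alone, the read-out also runs no change at the digits printed from compound 1 to compound 4 (within the scatter), which adds a comparison the earlier compounds did not give: 4-methoxyphenyl and 2-methoxyphenyl, two groups whose names differ only in the number, are not told apart at this place. No evidence on any property of these compounds accompanies the result, so the flat steps stay plain observations.

The compounds shown hold only substituted phenyl groups at this place, and with every step flat, none of them marks out what, if anything, would move the read-out in this assay. Open, from the compounds shown here alone, is whether a phenyl group carrying a carboxylic acid or an amine, or a longer chain in place of the phenyl group, would separate from the level compounds here.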